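Swapping the Benzyl Group on a Cyanopyrimidine Core

The compounds below may be only part of what the source reports. "The series", "measured", "known", "first", "only" and "open" are said of these compounds alone.

Of the compounds shown here, two have been measured in a functional assay on B16-F10 cells (Mus musculus) for inhibition, read by MTT assay, with a stated time of 72 h; on this read-out lower numbers stand for stronger inhibition and higher numbers for weaker inhibition. Compound 2, `Cc1ccc(Nc2nc(SCc3cn(Cc4ccc(F)cc4)nn3)nc(-c3ccccc3)c2C#N)cc1`, gives 3040 nM, the lower of the two numbers. Within the data shown here, compound 1, `Cc1cccc(Nc2nc(SCc3cn(Cc4ccccc4Cl)nn3)nc(-c3ccccc3)c2C#N)c1`, gives 13500 nM in this assay, a gap beyond the usual scatter; compound 1 differs from compound 2 in two places, so no single step connects them.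

Compound 3, `Cc1ccc(Nc2nc(SCc3cn(Cc4ccccc4Cl)nn3)nc(-c3ccccc3)c2C#N)cc1`, has not yet been measured. It differs from compound 2 in one place: 2-chlorophenyl in place of 4-fluorophenyl on a saturated chain carbon bound to an aromatic nitrogen. Compound 1 carries this same 2-chlorobenzyl group, and its weaker number in this assay is the only hint available. The step of a 2.0-fold higher number from compound 2 to compound 3 (0.30 log units; within the scatter) is therefore expected to move toward a higher number, because compound 1 gives 13500 nM. Compound 3 is estimated at 6000 nM, within a range from 2500 nM to 15000 nM.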

Compound 3, half-maximal inhibitory concentration: 3390 nM
Estimate against measurement, compound 3: 1.8-fold (0.25 log units) above; low and high end bracket the measured number.
By their numbers in this assay, from the lowest: compounds 2 and 3 (each within the scatter of the next); then compound 1.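

In this assay, the step from 4-fluorobenzyl to 2-chlorobenzyl is a 1.1-fold higher number from compound 2 to compound 3 (0.05 log units; within the scatter), so these two groups cannot be told apart at this place, on a saturated chain carbon bound to an aromatic nitrogen. With 2-chlorobenzyl held fixed, 4-methylphenyl in place of 3-methylphenyl on a nitrogen on an aromatic ring gives a 4.0-fold lower number from compound 1 to compound 3 (0.60 log units; beyond the scatter), which places the gap to compound 1 at the nitrogen-bound aryl group rather than at the benzyl group. No measured evidence bears on the reason for either result.

Going by these compounds, whether the benzyl position would respond to a different kind of group, such as a benzyl carrying an amine or a carboxylic acid, or a longer chain, remains open. On these data alone, it is also open whether the methylphenyl step would look the same alongside 4-fluorobenzyl.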